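Swapping bromo for methoxy in a cytotoxicity series

This account rests on a few compounds, and the source may have more. Where it says the series, first, only, none or still open, it means among the compounds named here.

Compound 3 `Cc1[nH]c2ccccc2c1C(=O)/C(C#N)=C/C=C(\Cl)c1ccc(Br)cc1` and compound 1 `COc1ccc(/C(Cl)=C/C=C(\C#N)C(=O)c2c(C)[nH]c3ccccc23)cc1` share one core. In a functional assay on MCF7 cells (Homo sapiens) for cytotoxicity, read by sulforhodamine B assay, with a stated time of 48 h (on this read-out lower numbers stand for higher toxicity in this test and higher numbers for lower toxicity in this test), compound 3 gives only a limit of the assay, > 100000 nM. Compound 1 likewise gives only a limit in this assay, > 100000 nM. Their difference is methoxy in place of bromo on an aromatic carbon, and the step that the two limits leave unreadable from compound 3 to compound 1 cannot be sized because of the limit of > 100000 nM in this assay, at which 3 of the 3 values shown sit. Compound 2 `COc1cc(/C(Cl)=C/C=C(\C#N)C(=O)c2c[nH]c3ccc(Br)cc23)cc(OC)c1OC` carries a second core; how the two cores differ is not broken down here. Compound 2 gives only a limit in this assay, > 100000 nM. Compound 4 `COc1ccc2[nH]cc(C(=O)/C(C#N)=C/C=C(\Cl)c3cc(OC)c(OC)c(OC)c3)c2c1` differs from compound 2 by methoxy in place of bromo on an aromatic carbon, the same kind of change, but placed on a six-membered aromatic ring of carbon only that is part of a fused or bridged system of two rings, meta to a fused ring and para to a fused ring. Since the measured step remained unreadable, only a small step that the limit leaves unreadable from compound 2 to compound 4 is expected, and compound 4 is estimated at 150000 nM.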

Compound 4, concentration lethal to 50% of the cells: > 100000 nM
Compound 4 ended at the assay's limit; the forecaster's own chance of this, stated with the estimate: 85%; the middle value is on the limit's open side.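

Compound 2 and compound 4 both give only a limit of the assay, so no step between them can be read, because of this: the limit of > 100000 nM in this assay, at which 4 of the 4 values shown sit.

The compounds shown leave open whether methoxy in place of bromo changes cytotoxicity at all.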